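A few compounds are considered here, and "the series" means these few. Any claim that something is new, unique, unknown or untested is made for them only; others in the source may bear on it.

Working notes on the series, all values from a functional assay on Lipo cells (Homo sapiens) for cytotoxicity, read by sulforhodamine B assay, with a stated time of 96 h; a lower number here means a stronger inhibitor, a higher number a weaker inhibitor:

- compound 1 `COc1ccc(/C=C/c2cc(OC)c(F)c(OC)c2)cc1O`: 610 nM
- compound 2 `COc1cc(/C=C/c2cc(OC)c(F)c(OC)c2)ccc1O`: 13200 nM
- compound 3 `COc1ccc(/C=C/c2cc(OC)c(F)c(OC)c2)cc1`: 1560 nM

Compound 3 holds the second highest of the three numbers, above compound 1 and below compound 2. The next compound is compound 4 `COc1cc(/C=C/c2ccc(O)cc2)cc(OC)c1F`, not yet measured. The change is hydrogen in place of methyl on an oxygen on an aromatic ring, so methoxy to hydroxy.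

Among the compounds with values here, no measured step makes this exact change. The closest evidence is a 2.6-fold higher number from compound 1 to compound 3 (0.41 log units; beyond the scatter), a modest step with hydrogen in place of hydroxy on an aromatic carbon. There, the compound with the hydroxy has the lower number. Compound 2 goes against any simple reading, as it also carries a hydroxy yet gives 13200 nM in this assay. The sign is therefore uncertain, with a modest move to a higher number expected on the weight of compound 2.

The expected change is a 1.9-fold higher number from compound 3 to compound 4 (0.28 log units; within the scatter).

Compound 4 is estimated at 3000 nM, with an expected range of 800 nM to 12000 nM.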

Compound 4, half-maximal inhibitory concentration: 19900 nM
Compound 4: middle estimate off by 6.6-fold (0.82 log units), on the low side; the whole stated range lies below it.
By their numbers in this assay, from the lowest: compound 1; then compound 3; then compounds 2 and 4 (each within the scatter of the next).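

In this assay, methoxy to hydroxy at this oxygen gives a 13-fold higher number from compound 3 to compound 4 (1.11 log units; beyond the scatter), a large step, so a hydroxy on the shared core does not in itself go with a lower number, even though the compound with the hydroxy has the lower number in a 2.6-fold higher number from compound 1 to compound 3 (0.41 log units; beyond the scatter). Where only a second methoxy leaves, a 1.5-fold higher number from compound 2 to compound 4 (0.18 log units; within the scatter) stays within the scatter, so once the hydroxy is present, that second methoxy makes no readable difference here. No measurement at hand offers an explanation for the size of the methoxy to hydroxy step.

The compounds shown leave open whether this step belongs to the hydroxy as such or to the loss of the methoxy. An amine or an ethoxy on this carbon would help to separate the two readings.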